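The source may hold more compounds than are shown below. What is called first, only, known or untested is meant among the compounds shown, and "the series" means these compounds.

Compound 1 `O=S(=O)(Nc1ccc2oc(-c3ccccc3)nc2c1)c1ccc(Cl)c(Cl)c1` in an assay on isolated protein for inhibition of malate dehydrogenase, mitochondrial (Sus scrofa), with stated times of 45 min and 30 min (on this read-out higher numbers stand for weaker inhibition and lower numbers for stronger inhibition), gives > 63000 nM, which is a limit of the assay rather than a number.
Compound 2 `O=S(=O)(Nc1ccc(-c2nc3ccccc3o2)cc1)c1ccccc1C(F)(F)F` in this assay gives > 63000 nM, again a limit.
Compound 3 `Cc1ccccc1S(=O)(=O)Nc1ccc(-c2nc3ccccc3o2)cc1` in this assay gives > 63000 nM, also a limit.

Compound 3 therefore stands where every measured compound stands, at the limit of > 63000 nM in this assay, at which 3 of the 3 values shown sit, and the numbers shown do not separate it from the others. Going by the values given here, the only single-point step among the measured compounds, a step that the two limits leave unreadable from compound 2 to compound 3, runs between two limits, so its size cannot be read. Compound 4 `O=S(=O)(Nc1ccc(-c2nc3ccccc3o2)cc1)c1ccc(F)cc1` differs from compound 3 by 4-fluorophenyl in place of 2-methylphenyl on a sulfonyl sulfur. Among the compounds with values here, no measured step touches this kind of change, and the one step that exists gives no size to lean on. With all three measured compounds sitting at the same limit, the expectation for compound 4 in this assay is that it too will most likely be reported only as a limit. The step that the limit leaves unreadable from compound 3 to compound 4 is thus expected to be none beyond the scatter. Compound 4 is estimated at 80000 nM, with a range from 30000 nM to 250000 nM.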

Compound 4, half-maximal inhibitory concentration: > 63000 nM
Compound 4: no number, only a limit; the forecaster's own chance of this, stated with the estimate: 85%; the middle value is on the limit's open side.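

Compound 3 and compound 4 both give only a limit of the assay, not a number, and the step from one to the other cannot be read. The compounds shown leave open what structure would give a readable value in this assay, as all of them sit at one point: the limit of > 63000 nM in this assay, at which 4 of the 4 values shown sit.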